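Ethyl for Vinyl on the Aromatic Oxygen: Expected Response

The compounds below may be only part of what the source reports. "The series", "measured", "known", "first", "only" and "open" are said of these compounds alone.

Compound 1: `C=COc1ccccc1OC(C)C1=NCCN1`, 0.48
Compound 2: `C=CCc1cccc(CC=C)c1OC(C)C1=NCCN1`, 0.9

In an assay on CHO cells with Alpha-2C adrenergic receptor (Homo sapiens) as the target (on this read-out lower numbers stand for smaller maximal responses and higher numbers for larger maximal responses), compound 1 stands lowest of the two measured compounds, with compound 2 lying higher by a gap beyond the usual scatter. Compound 3, `CCOc1ccccc1OC(C)C1=NCCN1`, has not yet been measured. It differs from compound 1 in one place: ethyl in place of vinyl on an oxygen on an aromatic ring. Going by the values given here, with no measured pair showing this exact change, only a small step is expected in this assay, likely upward but possibly within the scatter, so the expected step is a number 0.070 higher from compound 1 to compound 3 (within the scatter). Compound 3 is estimated at 0.55, between 0.35 and 0.8.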

Compound 3, intrinsic activity: the largest response reached, as a fraction of the reference agonist's: 0.45
Compound 3: the middle estimate sits 0.10 above what was measured; the range from low to high includes it.
By their numbers in this assay, from the lowest: compounds 3 and 1 (each within the scatter of the next); then compound 2.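

In this assay, putting ethyl in place of vinyl on an oxygen on an aromatic ring gives a number 0.030 lower from compound 1 to compound 3 (within the scatter). For this pair, then, removing the double bond of the vinyloxy group, with the count of heavy atoms unchanged, produces no readable change in maximal response. No available data explain why the two groups read alike. Still open, as far as these compounds go, is whether a longer chain such as propyl on this oxygen would also leave the response unchanged, and whether an amine in place of ethoxy would do the same.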